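The compounds below may be only part of what the source reports. "The series", "measured", "known", "first", "only" and "open" are said of these compounds alone.

Compound 1, `O=C(O)CCc1ccc(NCc2ccccc2)cc1`, gives 759 nM.
Compound 2, `O=C(O)CCc1ccc(CNc2ccccc2)cc1`, gives 21400 nM.
Compound 3, `O=C(O)CCc1ccc(OCc2cccc(Br)c2)cc1`, gives 89.1 nM.

These three numbers come from a functional assay on 1321-N1 cells for agonist activity at Free fatty acid receptor 1 (Homo sapiens), read by calcium flux; on this read-out lower numbers stand for an effect already at smaller amounts and higher numbers for an effect only at larger amounts of compound. Among them, compound 3 stands at the lowest number, and both gaps to the other two lie beyond the usual scatter: compound 1 stands clearly above it, and compound 2 stands far above both. Compound 3 is thus the most potent of the three on this read-out.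

The next compound, compound 4, `N#Cc1cccc(COc2ccc(CCC(=O)O)cc2)c1`, keeps everything in compound 3 except one group: cyano in place of bromo on an aromatic carbon, meta to a large group. For the measured compounds named here, no pair of measured compounds differs in just such a way, so there is no measured step to lean on; the three measured compounds differ from one another in several places at once. Given that the change is small, the step from compound 3 to compound 4 is expected to stay within the scatter or to be only a modest move toward a higher number. Compound 4 is therefore estimated to give about 160 nM, with a range from 50 nM to 500 nM. That estimate means a step of a 1.8-fold higher number from compound 3 to compound 4 (0.25 log units; within the scatter), expected to be small.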

Compound 4, half-maximal effective concentration: 525 nM
Estimate against measurement, compound 4: 3.3-fold (0.52 log units) below; measured number outside the range, above it.
By their numbers in this assay, from the lowest: compound 3; then compounds 4 and 1 (each within the scatter of the next); then compound 2.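

In this assay, putting cyano in place of bromo on an aromatic carbon, meta to a large group, gives a 5.9-fold higher number from compound 3 to compound 4 (0.77 log units; beyond the scatter) and so shows that this position responds to the choice of group. The earlier compounds shown here could not show this, since they differ from one another in several places at once, whereas this pair isolates a single change, and bromo comes out ahead of cyano here. Nothing available explains why this swap moves the number.

Still open, going by these compounds, is whether other groups at this same carbon, such as chloro, methyl or methoxy, would stand nearer to compound 3 or to compound 4. Also open, on these data alone, is whether bromo and cyano would keep this order on another carbon of the same ring.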